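The compounds below may be only part of what the source reports. "The series", "measured", "known", "first", "only" and "open" are said of these compounds alone.

In an ADME assay on MT4 cells (Homo sapiens) for cytotoxicity, read by MTT assay, with a stated time of 5 days (a higher number here means that more compound is tolerated, a lower number that less compound is tolerated), three compounds sharing one core have been measured: compound 1 `CCNc1cc(Oc2c(OC)cc3cc(C#N)ccc3c2OC)nc(Nc2ccc(C#N)cc2)n1`, compound 2 `COc1cc2cc(C#N)ccc2c(OC)c1Oc1cc(NC(C)C)nc(Nc2ccc(C#N)cc2)n1` and compound 3 `COc1cc2cc(C#N)ccc2c(OC)c1Oc1cc(NC(C)(C)C)nc(Nc2ccc(C#N)cc2)n1`. Compound 1 gives > 125000 nM, which is a limit. Compound 2 gives > 125000 nM, also a limit. Compound 3 gives > 125000 nM, again a limit. Compound 3 thus stands at the limit of > 125000 nM in this assay, at which 3 of the 3 values shown sit. Compound 4 `CCCCCC(C)Nc1cc(Oc2c(OC)cc3cc(C#N)ccc3c2OC)nc(Nc2ccc(C#N)cc2)n1` carries 1-methylhexyl in place of tert-butyl on a nitrogen on an aromatic ring. The nearest steps, a step that the two limits leave unreadable from compound 1 to compound 2, a step that the two limits leave unreadable from compound 1 to compound 3 and a step that the two limits leave unreadable from compound 2 to compound 3, have no readable size, so they give no measure for this change. A modest fall in the tolerated concentration is expected, though only tentatively. The expected step is an at least 1.5-fold lower number from compound 3 to compound 4 (0.19 log units; that floor lies within the scatter). Compound 4 is estimated at 80000 nM, with a range from 25000 nM to 125000 nM.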

Compound 4, half-maximal cytotoxic concentration: > 125000 nM
Compound 4: a limit, no number (the forecaster's own chance of this, stated with the estimate: 50%); middle value at least 1.5-fold (0.19 log units) away from the limit.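

Going by these compounds alone, compound 4 joins compound 1, compound 2 and compound 3 as a limit, so no step among them can be read in this assay: the limit of > 125000 nM in this assay, at which 4 of the 4 values shown sit. The compounds shown leave open what concentration each tolerates, and whether the group on the nitrogen changes it.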